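Hydroxycyclohexenyl in place of the aromatic ring on the core

The source may hold more compounds than are shown below. What is called first, only, known or untested is meant among the compounds shown, and "the series" means these compounds.

Compound 1 `C[C@@H](O[C@H]1CN2C(=O)C=C(c3ccc(CO)cc3)CC2[C@@H]1c1ccc(F)cc1)c1cc(C(F)(F)F)cc(C(F)(F)F)c1`: 0.39 nM
Compound 2 `C[C@@H](O[C@H]1CN2C(=O)C=C(c3ccncc3)CC2[C@@H]1c1ccc(F)cc1)c1cc(C(F)(F)F)cc(C(F)(F)F)c1`: 0.14 nM
Compound 3 `C[C@@H](O[C@H]1CN2C(=O)C=C(c3ccc[n+]([O-])c3)CC2[C@@H]1c1ccc(F)cc1)c1cc(C(F)(F)F)cc(C(F)(F)F)c1`: 0.15 nM

Of the compounds shown here, three sharing one core have been measured in an assay on CHO cells for displacement of a labelled ligand from Substance-P receptor (Homo sapiens); on this read-out lower numbers stand for stronger inhibition and higher numbers for weaker inhibition. Compound 3 gives 0.15 nM and stands second highest of the three numbers, though its gap to compound 2 is within the scatter, while compound 1 sits higher by a step beyond the scatter.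

Compound 4 `C[C@@H](O[C@H]1CN2C(=O)C=C(C3=CCC(O)CC3)CC2[C@@H]1c1ccc(F)cc1)c1cc(C(F)(F)F)cc(C(F)(F)F)c1` has not yet been measured. The change from compound 3 is a group of 7 heavy atoms (6 carbon, 1 oxygen; one six-membered non-aromatic ring of carbon only) in place of a group of 7 heavy atoms (5 carbon, 1 nitrogen, 1 oxygen; one six-membered aromatic ring with 1 hetero atom), on a double-bonded ring carbon; the entering group has one hydrogen-bond donor and one acceptor, and its ring carries a double bond outside aromatic rings.

The measured steps bear on this only loosely. The steps of a 2.8-fold lower number from compound 1 to compound 2 (0.44 log units; beyond the scatter) and a 2.6-fold lower number from compound 1 to compound 3 (0.41 log units; beyond the scatter) show that replacing the hydroxymethylphenyl group of compound 1 with either six-membered aromatic ring with one hetero atom gives a modest improvement, and the step of a 1.1-fold higher number from compound 2 to compound 3 (0.03 log units; within the scatter) is within the scatter. Among the measured compounds shown here, no measured step replaces the aromatic ring with a non-aromatic one, so the expectation rests on the hydroxyl-bearing compound 1 0.39 nM as the nearest point of reference. A modest weakening in this assay is therefore expected, a 3.0-fold higher number from compound 3 to compound 4 (0.48 log units; beyond the scatter), with wide uncertainty. Compound 4 is estimated at 0.45 nM, in the range 0.12 nM to 1.8 nM.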

Compound 4, half-maximal inhibitory concentration: 0.18 nM
Beside the measured number, compound 4's estimate is 2.5-fold (0.40 log units) above it; the range from low to high includes it.
By their numbers in this assay, from the lowest: compounds 2, 3 and 4 (each within the scatter of the next); then compound 1.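

In this assay, the double-bonded ring carbon of the shared core now proves to accept a non-aromatic ring, with 4-hydroxycyclohex-1-en-1-yl matching the aromatic rings with a hetero atom: a 1.2-fold higher number from compound 3 to compound 4 (0.08 log units; within the scatter) and a 1.3-fold higher number from compound 2 to compound 4 (0.11 log units; within the scatter) are both small enough to leave these compounds level. The same entering group, set against 4-(hydroxymethyl)phenyl, gives a 2.2-fold lower number from compound 1 to compound 4 (0.34 log units; beyond the scatter) and so shows that, among these four compounds, an aromatic ring at this place is not required for a number in the range of compound 2 and compound 3, while compound 1 shows that an aromatic ring alone does not secure one. No measurement offers an explanation for how closely these different groups agree.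

As far as these compounds go, it remains open whether the hydroxyl on the new ring matters at all, a question that a plain cyclohex-1-en-1-yl group would address. From the compounds shown here alone, it is equally open how this position would respond to a primary amine or a carboxylic acid in place of that hydroxyl, or to a fully saturated cyclohexyl ring in place of the cyclohexenyl ring.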